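Swapping an isopropyl for an aryl group on the ether oxygen

A few compounds are considered here, and "the series" means these few. Any claim that something is new, unique, unknown or untested is made for them only; others in the source may bear on it.

Compounds measured so far:
Compound 1, `CC(C)Oc1ccc(C(C)(C)O)cc1-c1cn(C)c(=O)c2[nH]c(C(=O)NCc3ccc(C(=O)NO)cc3)cc12`: 350 nM
Compound 2, `CC(C)Oc1ccc(C(C)(C)O)cc1-c1cn(C)c(=O)c2[nH]c(C(=O)NCCCCCCC(=O)NO)cc12`: 160 nM
Compound 3, `Cn1cc(-c2ccccc2Oc2ccccc2)c2cc(C(=O)NCCCCCC(=O)NO)[nH]c2c1=O`: 610 nM

All three compounds share a core and carry a hydroxamic acid on an amide-linked side chain; they were tested in a functional assay on MV4-11 cells (Homo sapiens) for antiproliferative activity, read by CCK-8 assay, with a stated time of 72 h; on this read-out lower numbers stand for stronger inhibition and higher numbers for weaker inhibition. Compound 1 stands second highest of the three numbers: compound 3 lies within the scatter of it, while compound 2 sits clearly lower, as the step of a 2.2-fold lower number from compound 1 to compound 2 (0.34 log units; beyond the scatter) shows.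

Compound 4, `Cc1cc(F)cc(C)c1Oc1ccc(C(C)(C)O)cc1-c1cn(C)c(=O)c2[nH]c(C(=O)NCc3ccc(C(=O)NO)cc3)cc12`, is not yet measured. It differs from compound 1 only at the ether oxygen: 4-fluoro-2,6-dimethylphenyl in place of isopropyl on an oxygen on an aromatic ring

Within the data shown here, no measured step bears directly on this change. Among the measured compounds shown here, the one step known, from compound 1 to compound 2, alters the hydroxamate side chain, not the ether. Compound 3 carries an aryl on its ether oxygen, but it also lacks the hydroxypropan-2-yl group and has a different chain, so its value of 610 nM says nothing clean about the ether alone. With no guide, compound 4 is expected to stay close to compound 1, a step of a 1.1-fold higher number from compound 1 to compound 4 (0.06 log units; within the scatter), within the scatter. Compound 4 is therefore estimated at 400 nM, with a range from 150 nM to 1100 nM.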

Compound 4, half-maximal inhibitory concentration: 440 nM
The estimate for compound 4 lay 1.1-fold (0.04 log units) below the measured number, within the range that was stated.
By their numbers in this assay, from the lowest: compound 2; then compounds 1, 4 and 3 (each within the scatter of the next).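

In this assay, replacing isopropyl (3 heavy atoms, no ring) with 4-fluoro-2,6-dimethylphenyl (9 heavy atoms, one aromatic ring) on the oxygen gives a 1.3-fold higher number from compound 1 to compound 4 (0.10 log units; within the scatter), so this change leaves the number where it was. Among these compounds, with the 4-(hydroxycarbamoyl)phenyl side chain held constant, this position therefore accepts either an open alkyl group or a substituted aromatic ring, something the earlier compounds could not show because none of them isolated the ether. No measurement available here accounts for this result.

As far as these compounds go, whether the same swap would behave alike with the 5-(hydroxycarbamoyl)pentyl side chain of compound 2 remains open. Also open, from the compounds shown here alone, are the effect of a plain methyl or an amine-bearing chain on this oxygen, and whether the fluorine or the two methyl groups matter on their own.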